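Sulfonamide variation at the pyridine-bearing position of the series

This account rests on a few compounds, and the source may have more. Where it says the series, first, only, none or still open, it means among the compounds named here.

Among the compounds with values here, compound 3 `CC(C)(C)c1ccc(NC(=O)c2ccc(-c3ncccc3N(S(C)(=O)=O)S(C)(=O)=O)cc2)cc1` stands lowest among the three measured members: in a functional assay for antagonist activity at transient receptor potential cation channel subfamily V member 1 (Rattus norvegicus) (on this read-out lower numbers stand for stronger inhibition and higher numbers for weaker inhibition), compound 3 gives 0.4 nM, against 13 nM for compound 2 `CC(C)(C)c1ccc(NC(=O)c2ccc(-c3ncccc3C#N)cc2)cc1` and 20 nM for compound 1 `CCCOc1cccnc1-c1ccc(C(=O)Nc2ccc(C(C)(C)C)cc2)cc1`. Compound 4 `CC(C)(C)c1ccc(NC(=O)c2ccc(-c3ncccc3NS(=O)(=O)c3ccccc3)cc2)cc1` is unmeasured and differs from compound 3 only in that ((phenylsulfonyl)amino in place of bis(methylsulfonyl)amino on an aromatic carbon). Within the data shown here, the steps that bear on this change are a 50-fold lower number from compound 1 to compound 3 (1.70 log units; beyond the scatter) and a 33-fold lower number from compound 2 to compound 3 (1.51 log units; beyond the scatter), both large gains on arrival of the bis(methylsulfonyl)amino group; no measured step removes one of its two methylsulfonyl arms or exchanges one for a phenylsulfonyl. Part of that gain is expected to be kept, so the step from compound 3 to compound 4 is expected as a 7.5-fold higher number from compound 3 to compound 4 (0.88 log units; beyond the scatter), a moderate rise. Compound 4 is therefore estimated at 3 nM, within 0.5 nM to 20 nM.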

Compound 4, half-maximal inhibitory concentration: 166 nM
Compound 4: the middle estimate sits 55-fold (1.74 log units) below what was measured; measured number outside the range, above it.
By their numbers in this assay, from the lowest: compound 3; then compounds 2 and 1 (each within the scatter of the next); then compound 4.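

In this assay this position does not reward every sulfonyl-bearing group: (phenylsulfonyl)amino in place of bis(methylsulfonyl)amino gives a 420-fold higher number from compound 3 to compound 4 (2.62 log units; beyond the scatter) and removes the whole gain seen with compound 3. The same group also compares poorly with the smaller substituents, with a 13-fold higher number from compound 2 to compound 4 (1.11 log units; beyond the scatter) and an 8.3-fold higher number from compound 1 to compound 4 (0.92 log units; beyond the scatter) on this read-out, so a sulfonyl group on this nitrogen does not alone bring a low number. Nothing at hand explains the rise.

Still open, as far as these compounds go, is whether the phenyl ring or the missing second sulfonyl arm accounts for the rise. A single methylsulfonylamino group at this position would separate the two.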